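From 4-fluorophenyl to allyl on a cytotoxic compound

The compounds below may be only part of what the source reports. "The series", "measured", "known", "first", "only" and "open" are said of these compounds alone.

In a functional assay on T47D cells (Homo sapiens) for cytotoxicity, read by MTT assay, with a stated time of 48 h (on this read-out higher numbers stand for weaker inhibition and lower numbers for stronger inhibition), compound 1 (`Fc1ccc(NC(=S)N/N=C\c2ccnc3ccccc23)cc1`) gives 1070 nM and compound 2 (`S=C(N/N=C\c1ccnc2ccccc12)Nc1cccc2ccccc12`) gives 1210 nM and these two values lie within the usual scatter of each other. Compound 3 (`C=CCNC(=S)N/N=C\c1ccnc2ccccc12`) has no measured value yet. The change (allyl in place of 4-fluorophenyl on an amide-type nitrogen) puts allyl in place of 4-fluorophenyl on an amide-type nitrogen. Among the compounds with values here, no measured pair shows this kind of change, so any forecast here is loose. A moderate move toward weaker inhibition is expected in this assay (a 2.3-fold higher number from compound 1 to compound 3 (0.37 log units; beyond the scatter)). For compound 3 the estimated value is 2500 nM with a wide expected range (700 nM to 9000 nM).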

Compound 3, half-maximal inhibitory concentration: 1230 nM
The estimate for compound 3 lay 2.0-fold (0.31 log units) above the measured number; the measured number falls inside the stated range.
By their numbers in this assay, from the lowest: compounds 1, 2 and 3 (each within the scatter of the next).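

In this assay, putting allyl in place of 4-fluorophenyl on the amide-type nitrogen gives a 1.1-fold higher number from compound 1 to compound 3 (0.06 log units; within the scatter). This shows something the first two compounds could not: the number holds even when the six-membered aromatic ring leaves and a smaller group with no ring enters. For this pair, an aromatic ring at this position is not needed to keep the value.

From the compounds shown here alone, whether a longer chain or a carboxylic acid in the same place would also leave the value unchanged remains open. No measurement shown explains why this change leaves the value within the scatter.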